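Cyclohexyl for trifluoromethylphenyl on the shared core

The compounds below may be only part of what the source reports. "The series", "measured", "known", "first", "only" and "open" are said of these compounds alone.

Compound 1 `FC(F)(F)c1ccc(-c2ccc3c(NCCCNCc4ccco4)ccnc3c2)cc1` gives 32000 nM in a physicochemical assay for solubility, with a stated time of 18 h, at pH 7.4; a higher number here means a more soluble compound, a lower number a less soluble compound. Compound 2 `COc1cccc(CNCCCNc2ccnc3cc(-c4ccc(C(F)(F)F)cc4)ccc23)c1O` gives 32000 nM in this assay, and the step of no change at the digits printed from compound 1 to compound 2 (within the scatter) shows compound 1 level with compound 2 at the digits shown. Compound 3 `c1coc(CNCCCNc2ccnc3cc(C4CCCCC4)ccc23)c1` differs from compound 1 by cyclohexyl in place of 4-(trifluoromethyl)phenyl on an aromatic carbon. Among the compounds with values here, the only measured step concerns the group on the saturated chain carbon, not this aromatic carbon, so no measured step bears on the change. In this assay compound 3 is expected near 32000 nM, between 8000 nM and 100000 nM. The expected step is no change at the digits printed from compound 1 to compound 3 (within the scatter), none beyond the scatter.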

Compound 3, solubility: 4200 nM
The estimate for compound 3 lay 7.6-fold (0.88 log units) above the measured number, outside the stated range (below it).
By their numbers in this assay, from the lowest: compound 3; then compounds 1 and 2 (each within the scatter of the next).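

In this assay, within the data shown here, the aromatic carbon carrying 4-(trifluoromethyl)phenyl gives the first step beyond the scatter, a 7.6-fold lower number from compound 1 to compound 3 (0.88 log units; beyond the scatter). The earlier step, on the saturated chain carbon, left the number level, so this aromatic carbon responds where that position did not. No accompanying measurement bears on why this step occurs.

The compounds shown do not separate loss of the aromatic ring from loss of the trifluoromethyl group; an unsubstituted phenyl or a piperidine on this aromatic carbon would address that. Going by these compounds, whether 2-hydroxy-3-methoxyphenyl in place of furan-2-yl stays level alongside cyclohexyl also remains open.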